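The source may hold more compounds than are shown below. What is called first, only, known or untested is meant among the compounds shown, and "the series" means these compounds.

Series notes. In a functional assay on MCF7 cells (Homo sapiens) for cytotoxicity, read by MTT assay, with a stated time of 48 h (a higher number here means that more compound is needed for the effect, a lower number that less compound is needed), compound 1 `Cc1c(O)c(=O)ccn1CC(=O)N/N=C1\C(=O)N(CC(=O)Nc2ccc(Br)cc2)c2ccccc21` gives 32500 nM. In this assay compound 2 `Cc1ccc(NC(=O)CN2C(=O)/C(=N\NC(=O)Cn3ccc(=O)c(O)c3C)c3ccccc32)cc1` gives 52200 nM, and compound 3 `Cc1cccc(NC(=O)CN2C(=O)/C(=N\NC(=O)Cn3ccc(=O)c(O)c3C)c3ccccc32)c1C` gives 51900 nM. The steps of a 1.6-fold higher number from compound 1 to compound 2 (0.21 log units; within the scatter) and a 1.6-fold higher number from compound 1 to compound 3 (0.20 log units; within the scatter) are within the scatter, as is a 1.0-fold lower number from compound 2 to compound 3 (0.00 log units; within the scatter); compound 3 therefore sits at the same level as compound 2 and cannot be set apart from compound 1 either, so the three numbers read as one level. Compound 4 `Cc1c(O)c(=O)ccn1CC(=O)N/N=C1\C(=O)N(CC(=O)Nc2cccc(Cl)c2)c2ccccc21` has not yet been measured in this assay. The change is 3-chlorophenyl in place of 2,3-dimethylphenyl on an amide-type nitrogen. Among the measured compounds shown here, two measured steps concern exchanges of the group on this amide-type nitrogen, a 1.6-fold higher number from compound 1 to compound 3 (0.20 log units; within the scatter) and a 1.0-fold lower number from compound 2 to compound 3 (0.00 log units; within the scatter), and a third, a 1.6-fold higher number from compound 1 to compound 2 (0.21 log units; within the scatter), exchanges bromo for methyl within the same aryl group; none of them moved the number beyond the scatter, and a halogen-bearing aryl in compound 1 gave no different reading from the methyl-bearing aryl in compound 2. The expectation is therefore no step beyond the scatter for a 1.2-fold lower number from compound 3 to compound 4 (0.06 log units; within the scatter). Compound 4 is estimated at 45000 nM, with a range from 20000 nM to 100000 nM.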

Compound 4, half-maximal effective concentration: 34600 nM
Beside the measured number, compound 4's estimate is 1.3-fold (0.11 log units) above it, and the stated range covers the measured number.
By their numbers in this assay, from the lowest: compounds 1, 4, 3 and 2 (each within the scatter of the next).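

In this assay, a chlorine-bearing aryl group on the amide-type nitrogen also stays within the scatter of the earlier groups: a 1.5-fold lower number from compound 3 to compound 4 (0.18 log units; within the scatter), a 1.5-fold lower number from compound 2 to compound 4 (0.18 log units; within the scatter) and a 1.1-fold higher number from compound 1 to compound 4 (0.03 log units; within the scatter). Among the compounds shown here, the level shared by the series now spans four aryl groups, 4-bromophenyl, 4-methylphenyl, 2,3-dimethylphenyl and 3-chlorophenyl, and no compound among the four goes against it, so none of these exchanges sets one compound apart from another. No available evidence bears on why the number holds across these exchanges.

On these data alone, whether a group without an aromatic ring on this nitrogen, such as cyclohexyl or a longer alkyl chain, or a phenyl carrying an amine or a carboxylic acid, would move the number beyond the scatter remains open. Also open, as far as these compounds go, is what an exchange elsewhere on the shared core would do.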